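Removing the bromine from a weakly inhibiting acetophenone

The source may hold more compounds than are shown below. What is called first, only, known or untested is meant among the compounds shown, and "the series" means these compounds.

Measured compounds:
Compound 1, `CCOc1cc(OC)c(Br)cc1C(C)=O`, gives 46800000 nM.
Compound 2, `CCCCCCOc1cc(OC)c(Br)cc1C(C)=O`, gives 42400000 nM.
Compound 3, `CCCCCCCCOc1cc(OC)c(Br)cc1C(C)=O`, gives 39000000 nM.

These three values were obtained in a functional assay, with a stated time of 30 min; on this read-out higher numbers stand for weaker inhibition and lower numbers for stronger inhibition. Compound 1 has the highest of the three numbers, but its steps to compound 2, a 1.1-fold lower number from compound 1 to compound 2 (0.04 log units; within the scatter), and to compound 3, a 1.2-fold lower number from compound 1 to compound 3 (0.08 log units; within the scatter), both lie within the scatter, as does the step of a 1.1-fold lower number from compound 2 to compound 3 (0.04 log units; within the scatter). Lengthening the alkoxy chain on the shared core therefore left the read-out essentially unchanged across all three compounds.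

Compound 4, `CCOc1cc(OC)ccc1C(C)=O`, has not yet been measured. It differs from compound 1 in one place: hydrogen in place of bromo on an aromatic carbon.

Among the measured compounds shown here, none of the measured steps bears on this change; all three concern the alkoxy chain, not the bromine on the aromatic carbon. For the measured compounds named here, there is thus no precedent within this set for what removing the bromo substituent does, and the measured steps only show that the read-out is insensitive to at least one kind of variation on the core. In the absence of a relevant step, compound 4 is expected to land near compound 1, with the step of a 1.1-fold higher number from compound 1 to compound 4 (0.03 log units; within the scatter) estimated to be of uncertain direction and a wide range is warranted. The estimate for compound 4 is 50000000 nM, between 15000000 nM and 160000000 nM.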

Compound 4, half-maximal inhibitory concentration: 39600000 nM
Beside the measured number, compound 4's estimate is 1.3-fold (0.10 log units) above it; low and high end bracket the measured number.
By their numbers in this assay, from the lowest: compounds 3, 4, 2 and 1 (each within the scatter of the next).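

In this assay the exchange of bromo for hydrogen gave a 1.2-fold lower number from compound 1 to compound 4 (0.07 log units; within the scatter) and thus no change that can be told from the scatter at this aromatic carbon, which lies ortho to a methoxy group, meta to an acetyl group and para to an ethoxy group. The earlier compounds had shown this flat behaviour only along the alkoxy chain, whereas compound 4 extends it to a second place on the shared core: the read-out of compound 1 does not depend on the bromine, a single heavy atom, being present. No measurement available here accounts for this lack of response.

As far as these compounds go, whether any other group on this aromatic carbon, such as an amine, a carboxylic acid or a nitrile, would move the number beyond the scatter remains open. So does the question of whether the read-out responds at all to a change elsewhere on the shared core, for instance replacing the acetyl group with a carboxylic acid or the methoxy group with a longer chain.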